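The source may report more compounds than this note shows. Statements on the series, on what has been measured and on what is new or still open speak of the compounds shown alone.

Three compounds share one core and differ only in the group that sits on a saturated chain carbon bound to an aromatic nitrogen. Compound 1 `O=c1ccoc2cc(OCc3cn(Cc4ccccc4)nn3)ccc12` carries a plain benzyl there, and in a functional assay on HeLa cells (Homo sapiens) for cytotoxicity, read by MTT assay, with a stated time of 48 h (a higher number here means a weaker inhibitor, a lower number a stronger inhibitor), compound 1 gives > 100000 nM, which is a limit of the assay rather than a number. Compound 2 `Cc1ccc(Cn2cc(COc3ccc4c(=O)ccoc4c3)nn2)cc1` has a methyl in place of hydrogen on an aromatic carbon of that benzyl, and in this assay compound 2 gives > 100000 nM, again a limit. Within the data shown here, compound 3 `O=c1ccoc2cc(OCc3cn(Cc4ccc(F)cc4)nn3)ccc12` has a fluoro on an aromatic carbon instead, and in this assay compound 3 gives 12000 nM, the only true number of the three, the other two sitting at the limit of > 100000 nM in this assay, at which 2 of the 3 values shown sit. The step from hydrogen to fluoro is an at least 8.3-fold lower number from compound 1 to compound 3 (0.92 log units; beyond the scatter), and from methyl to fluoro an at least 8.3-fold lower number from compound 2 to compound 3 (0.92 log units; beyond the scatter); both start from a limit, so only their smallest possible size is known. The step that the two limits leave unreadable from compound 1 to compound 2 cannot be read.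

Compound 4 `N#Cc1cccc(Cn2cc(COc3ccc4c(=O)ccoc4c3)nn2)c1` introduces the change (3-cyanophenyl in place of 4-fluorophenyl on a saturated chain carbon bound to an aromatic nitrogen). Among the measured compounds shown here, no measured step involves a cyanophenyl group, so the measured steps only show that losing the fluoro cost at least a modest amount of potency. Compound 4 is therefore expected to give 35000 nM, with a range from 6000 nM to 150000 nM. That expectation corresponds to an estimated step of a 2.9-fold higher number from compound 3 to compound 4 (0.46 log units; beyond the scatter).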

Compound 4, half-maximal inhibitory concentration: > 100000 nM
Compound 4 gave a limit, no number (the forecaster's own chance of this, stated with the estimate: 40%); middle value at least 2.8-fold (0.45 log units) from the limit.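

In this assay, 3-cyanophenyl in place of 4-fluorophenyl on a saturated chain carbon bound to an aromatic nitrogen brings an at least 8.3-fold higher number from compound 3 to compound 4 (0.92 log units; beyond the scatter), and the value of compound 4 is a limit of the assay, not a number, so this step too gives only its smallest possible size. The earlier compounds shown here showed that plain phenyl and 4-methylphenyl do not match 4-fluorophenyl at this place, and compound 4 now adds a nitrile-bearing ring to those that do not match it, leaving compound 3 as the only one of the four with a true number: the limit of > 100000 nM in this assay, at which 3 of the 4 values shown sit. The steps from compound 1 and from compound 2 to compound 4 join two limits and cannot be read.

The group and the number in its name change together from 4-fluorophenyl to 3-cyanophenyl, so the compounds shown cannot tell which of the two changes matters. On these data alone, whether a ring carrying chloro, an amine or a carboxylic acid would give a true number also stays open, and so does how such a number would compare with compound 3 and its 12000 nM.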